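Replacing the butylamino group of compound 2

The compounds below may be only part of what the source reports. "The series", "measured", "known", "first", "only" and "open" are said of these compounds alone.

Compound 1 `Cc1nc(N2CCCCC2)c2nnn(-c3ccc(C(C)C)cc3Br)c2n1` gives 46 nM in an in vitro assay on 293-EBNA cells for binding affinity to corticotropin-releasing factor receptor 1 (Homo sapiens); on this read-out lower numbers stand for stronger inhibition and higher numbers for weaker inhibition; compound 2 `CCCCNc1nc(C)nc2c1nnn2-c1ccc(C(C)C)cc1Br` gives 69.6 nM in the same test. The step of a 1.5-fold higher number from compound 1 to compound 2 (0.18 log units; within the scatter) is the only measured one, so compound 2 holds the higher of the two numbers, though that gap stays within the scatter. Compound 3 `COCC(COC)Oc1nc(C)nc2c1nnn2-c1ccc(C(C)C)cc1Br` carries a group of 8 heavy atoms (5 carbon, 3 oxygen; no ring) in place of a group of 5 heavy atoms (4 carbon, 1 nitrogen; no ring), on an aromatic carbon. Among the compounds with values here, no measured step exchanges a nitrogen-linked group for an oxygen-linked one, so the earlier step offers little guidance. Compound 3 is therefore expected to land near compound 2 or somewhat weaker, a step of a 1.7-fold higher number from compound 2 to compound 3 (0.24 log units; within the scatter), with an estimate of 120 nM and a range from 40 nM to 400 nM.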

Compound 3, inhibition constant: 7.1 nM
For compound 3 the middle estimate is 17-fold (1.23 log units) above the measured one; measured number below the stated range.
By their numbers in this assay, from the lowest: compound 3; then compounds 1 and 2 (each within the scatter of the next).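

At this aromatic carbon, butylamino and piperidin-1-yl had stayed within the scatter of each other, but the group of 8 heavy atoms (5 carbon, 3 oxygen; no ring) gives a clear separation in this assay, with a 9.8-fold lower number from compound 2 to compound 3 (0.99 log units; beyond the scatter) and a 6.5-fold lower number from compound 1 to compound 3 (0.81 log units; beyond the scatter) on the two comparisons. The position therefore responds to the group it carries. No measurement shown bears on why the number falls.

The compounds shown leave open whether the linking oxygen or the two methoxymethyl arms account for the change. An amine bearing the same arms or a plain isopropoxy group would separate the two.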